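Second methyl on the phenyl ether of compound 3

A few compounds are considered here, and "the series" means these few. Any claim that something is new, unique, unknown or untested is made for them only; others in the source may bear on it.

Going by the values given here, compound 3 `Cc1cccc(Oc2ccc(CC3SC(=O)NC3=O)cc2)c1` gives the lowest number of the three measured so far: in a functional assay for agonist activity at Free fatty acid receptor 1 (Homo sapiens), read by FLIPR, in the presence of a further agent that is not named here (on this read-out lower numbers stand for an effect already at smaller amounts and higher numbers for an effect only at larger amounts of compound), compound 3 gives 203 nM, against compound 1 `Cc1cccc(Oc2ccc(CC3SC(=O)NC3=O)cc2)n1` with 2620 nM and compound 2 `Cc1ccnc(Oc2ccc(CC3SC(=O)NC3=O)cc2)c1` with 4280 nM. The gaps are a 13-fold lower number from compound 1 to compound 3 (1.11 log units; beyond the scatter) and a 21-fold lower number from compound 2 to compound 3 (1.32 log units; beyond the scatter), both large, whereas a 1.6-fold higher number from compound 1 to compound 2 (0.21 log units; within the scatter) stays within the scatter.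

Compound 4 `Cc1cc(C)cc(Oc2ccc(CC3SC(=O)NC3=O)cc2)c1` differs from compound 3 by methyl in place of hydrogen on an aromatic carbon; it sits meta to a large group and meta to a methyl group on the ring of carbon only. Among the compounds with values here, none of the measured steps adds a methyl to a ring that already carries one: the two large steps exchange a pyridine-based group for the 3-methylphenyl group, and the small step moves a methyl within a pyridine-based group. Within the data shown here, the change in compound 4 therefore has no direct precedent, and a step of a 1.3-fold lower number from compound 3 to compound 4 (0.10 log units; within the scatter) is expected, which is within the scatter. For compound 4 the estimate in this assay is 160 nM, with a range from 50 nM to 500 nM.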

Compound 4, half-maximal effective concentration: 96 nM
Compound 4: middle estimate off by 1.7-fold (0.22 log units), on the high side; the measured number falls inside the stated range.
By their numbers in this assay, from the lowest: compound 4; then compound 3; then compounds 1 and 2 (each within the scatter of the next).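

In this assay, methyl in place of hydrogen on the aromatic carbon meta to a large group and meta to a methyl group gives a 2.1-fold lower number from compound 3 to compound 4 (0.33 log units; beyond the scatter), a modest step. Going by these compounds alone, this position on the ring of carbon only therefore takes a second methyl with a lower number, something the earlier steps could not show, since they only exchanged a pyridine-based group for the 3-methylphenyl group or moved a methyl within a pyridine-based group. Nothing available explains why the added methyl has this effect.

On these data alone, whether the step is particular to methyl remains open, as an ethyl group, a chlorine atom or a methoxy group on the same carbon could give a different number. Also open, as far as these compounds go, is whether a second methyl would give a similar step on the pyridine-based group of compound 1.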